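Swapping the Amine Ring on a Cytotoxicity Probe

A few compounds are considered here, and "the series" means these few. Any claim that something is new, unique, unknown or untested is made for them only; others in the source may bear on it.

In an ADME assay on HL-60 cells (Homo sapiens) for cytotoxicity, read by resazurin assay, with a stated time of 72 h (a higher number here means that more compound is needed for the effect, a lower number that less compound is needed), compound 1 `NCCCCCCC(=O)Nc1nc2ccc(C(=O)c3ccccc3)cc2[nH]1` gives only a limit, > 30000 nM. Compound 2 `CN1CCC(CCn2c(N)nc3ccc(C(=O)c4ccccc4)cc32)CC1` likewise gives only a limit in this assay, > 30000 nM. On the numbers shown, compound 2 thus stands at the limit of > 30000 nM in this assay, at which 2 of the 2 values shown sit. Compound 3 `CN1CCC[C@H]1CCn1c(N)nc2ccc(C(=O)c3ccccc3)cc21` differs from compound 2 by a single change: 1-methylpyrrolidin-2-yl in place of 1-methylpiperidin-4-yl on a saturated chain carbon, two bonds along the chain from an aromatic nitrogen. Going by the values given here, with no measured step between compounds to lean on, the expected change in this assay is none beyond the scatter: a number no higher from compound 2 to compound 3 (the limit leaves the size open). Compound 3 is therefore estimated at 30000 nM, within 10000 nM to 100000 nM, most probably reported again only as a limit.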

Compound 3, half-maximal effective concentration: > 30000 nM
Compound 3 was reported as a limit; the forecaster's own chance of this, stated with the estimate: 85%; the middle value sits exactly at the limit.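

Compound 2 and compound 3 are each reported only as a limit, and no step can be read between them. The compounds shown leave open how much of either is needed for the effect, and whether the ring swap changes that amount at all.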